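A few compounds are considered here, and "the series" means these few. Any claim that something is new, unique, unknown or untested is made for them only; others in the source may bear on it.

Compound 1 `Cc1cc(C(=O)O)nn1Cc1cc(Br)ccc1OCc1ccc(Cl)cc1Cl` gives 0.49 nM in a functional assay on CHO-K1 cells for antagonist activity at prostaglandin E2 receptor EP1 subtype (Homo sapiens), read by FLIPR; a lower number here means a stronger inhibitor, a higher number a weaker inhibitor.
Compound 2 `Cc1cc(C(=O)O)nn1Cc1cc(Br)ccc1OCc1cccc(Cl)c1` gives 427 nM in this assay.
Compound 3 `Cc1cc(C(=O)O)nn1Cc1cc(Br)ccc1OCc1cccc([N+](=O)[O-])c1` gives 339 nM in this assay.

Compound 1 stands lowest of the three numbers, and so is the strongest inhibitor of the measured set. Its nearest neighbour is compound 3, reached by a 690-fold higher number from compound 1 to compound 3 (2.84 log units; beyond the scatter); the furthest is compound 2, reached by an 870-fold higher number from compound 1 to compound 2 (2.94 log units; beyond the scatter). Both of these steps replace the 2,4-dichlorophenyl group on the saturated chain carbon bound to the oxygen of the aromatic ring, and both are large. Between compound 2 and compound 3 the change is only a 1.3-fold lower number from compound 2 to compound 3 (0.10 log units; within the scatter), a swap of one small group for another on an aromatic carbon.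

Compound 4 `Cc1cc(C(=O)O)nn1Cc1cc(Cl)ccc1OCc1ccc(Cl)cc1Cl` keeps the 2,4-dichlorophenyl group intact and differs from compound 1 elsewhere: chloro in place of bromo on an aromatic carbon. Going by the values given here, no measured step touches this position, so neither large step bears on it directly. Among the compounds with values here, the only measured swap of one small group for another on an aromatic carbon, from compound 2 to compound 3, stayed within the scatter. The step from compound 1 to compound 4 is therefore expected to be small, a 1.4-fold higher number from compound 1 to compound 4 (0.15 log units; within the scatter), with no clear direction. Compound 4 is estimated at 0.7 nM, in a range from 0.25 nM to 2.5 nM.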

Compound 4, inhibition constant: 0.55 nM
For compound 4 the middle estimate is 1.3-fold (0.10 log units) above the measured one; measured number inside the range.
By their numbers in this assay, from the lowest: compounds 1 and 4 (each within the scatter of the next); then compounds 3 and 2 (each within the scatter of the next).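

In this assay, going by these compounds alone, chloro in place of bromo on this aromatic carbon gives a 1.1-fold higher number from compound 1 to compound 4 (0.05 log units; within the scatter), the first measured step at this position, and the two groups cannot be told apart by this read-out. The very strong inhibition of compound 1 therefore does not depend on bromo specifically: with the 2,4-dichlorophenyl group kept, compound 4 gives 0.55 nM, so chloro serves just as well at this carbon. The data shown offer no measurement that explains why these two groups behave alike.

Bromo and chloro are the only groups seen at this position, and each is a single atom, so it remains open whether a plain hydrogen, a methoxy group, a nitrile or an amine on the same carbon would leave the number as it is. As far as these compounds go, it is also open whether the swap of bromo for chloro would stay as quiet with the 3-chlorophenyl or 3-nitrophenyl group in place of the 2,4-dichlorophenyl group, since this one step was read with the 2,4-dichlorophenyl group alone.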